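Cyclopropyl for 4-methylphenyl on the alkyne

The source may hold more compounds than are shown below. What is called first, only, known or untested is meant among the compounds shown, and "the series" means these compounds.

Measured so far:
compound 1, `Cc1cccc(C#Cc2ccc(C(=O)N[C@H](C)C(C)(C)O)nc2)c1`: 68.6%
compound 2, `Cc1ccc(C#Cc2ccc(C(=O)N[C@H](C)C(C)(C)O)nc2)cc1`: 63.1%

In a functional assay on HEK293 cells for positive allosteric modulation of metabotropic glutamate receptor 5 (Rattus norvegicus), read by fluorescence and calcium flux (on this read-out lower numbers stand for smaller maximal responses and higher numbers for larger maximal responses), compound 2 stands at the lower of the two numbers, with compound 1 nearest to it: a number 5.5 percentage points lower from compound 1 to compound 2 (within the scatter). Compound 3, `C[C@@H](NC(=O)c1ccc(C#CC2CC2)cn1)C(C)(C)O`, has not been measured. It differs from compound 2 by cyclopropyl in place of 4-methylphenyl on a triple-bonded carbon. Within the data shown here, the only step recorded so far exchanges one methylphenyl for another on the same triple-bonded carbon and stays within the scatter, so it does not speak to the exchange of an aromatic ring for a cyclopropyl; no measured step bears directly on it. With nothing to anchor the change, the expectation for this assay is a small to moderate decrease, with wide uncertainty. Compound 3 is therefore expected to give 55%, with a range from 30% to 80%, which means an estimated step of a number 8.1 percentage points lower from compound 2 to compound 3 (within the scatter).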

Compound 3, largest response reached (reported as efficacy), in percent of the reference or control that the assay uses: 63.4%
Beside the measured number, compound 3's estimate is 8.4 percentage points below it, and the stated range covers the measured number.
By their numbers in this assay, from the lowest: compounds 2, 3 and 1 (each within the scatter of the next).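

In this assay, the triple-bonded carbon accepts a change of ring type and not only a shift of a methyl group: cyclopropyl, with 3 heavy atoms, in place of 4-methylphenyl, with 7, gives a number 0.3 percentage points higher from compound 2 to compound 3 (within the scatter), and cyclopropyl in place of 3-methylphenyl gives a number 5.2 percentage points lower from compound 1 to compound 3 (within the scatter). Among these compounds, then, a six-membered aromatic ring of carbon only is not needed at this place for the largest response to stay within the scatter. No measurement at hand accounts for the likeness of these groups.

The compounds shown leave open whether an amine, a carboxylic acid or a longer chain on the triple-bonded carbon would also stay within the scatter. They also leave open whether the shared core would respond in the same way to these exchanges if it were changed elsewhere.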